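A Methyl Added to the Aromatic Ring

The compounds below may be only part of what the source reports. "The series", "measured", "known", "first", "only" and "open" are said of these compounds alone.

Among the compounds with values here, compound 2 (`C=CC(=O)N1CC(NC(=O)Cn2cc(C(=O)N3CCc4c(cccc4OC)C3)c3cc(Br)ccc32)C1`) is one of two compounds measured so far. In a physicochemical assay for pharmacokinetics, read by LC-MS, in phosphate buffer, at pH 7.4, in the presence of a further agent that is not named here (on this read-out lower numbers stand for a shorter-lived compound and higher numbers for a longer-lived compound), compound 2 gives 1.67 h. Compound 1 (`C=CC(=O)N1CC(NC(=O)Cn2c(C)c(C(=O)N3CCc4c(cccc4OC)C3)c3cc(Br)cc(C)c32)C1`) gives 1.67 h in this assay, and the two values sit level with each other, within the scatter of the measurement.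

Compound 3 (`C=CC(=O)N1CC(NC(=O)Cn2cc(C(=O)N3CCc4c(cccc4OC)C3)c3cc(Br)cc(C)c32)C1`) has not yet been measured. It differs from compound 2 in one place: methyl in place of hydrogen on an aromatic carbon. Within the data shown here, no pair of measured compounds that differ in exactly this way is available, so the size of the step cannot be taken from a measured example. The two values shown give no sign of any movement, and the expected step from compound 2 to compound 3 in this assay is therefore none beyond the scatter, estimated as a 1.0-fold higher number from compound 2 to compound 3 (0.01 log units; within the scatter). Compound 3 is expected to give about 1.7 h in this assay, with a likely range from 0.9 h to 3.2 h.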

Compound 3, half-life: 1.67 h
For compound 3 the middle estimate is 1.0-fold (0.01 log units) above the measured one; the range from low to high includes it.
By their numbers in this assay, from the lowest: compounds 1, 2 and 3 (each within the scatter of the next).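

In this assay, a methyl on this aromatic carbon, ortho to a fused ring and meta to a bromo group, gives no change at the digits printed from compound 2 to compound 3 (within the scatter). The other methyl of compound 1 can now be read alone as well: hydrogen in place of that methyl on an aromatic carbon gives no change at the digits printed from compound 1 to compound 3 (within the scatter). Compound 1 and compound 2 differ in two places at once, so their matching values could have hidden two opposing steps, but each single step now shows no movement, and no measurement at hand offers an explanation.

Only hydrogen and methyl are shown on this carbon. An ethyl group, a methoxy group or an amine there could still read differently in this assay.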